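The source may report more compounds than this note shows. Statements on the series, on what has been measured and on what is new or still open speak of the compounds shown alone.

Measured so far in a functional assay on the whole organism for permeability, with Rattus norvegicus as the target, with a stated time of 4 h; a lower number here means that less compound is needed, a higher number that more compound is needed for the effect:
- compound 1 `O=C(O)c1cccc(CN2CCC(c3cn(Cc4ccoc4)c4ccccc34)CC2)c1`: 1 mg/kg
- compound 2 `CCCCn1cc(C2CCN(Cc3ccc(OC)c(C(=O)O)c3)CC2)c2ccccc21`: 0.08 mg/kg
- compound 3 `COc1ccc(CN2CCC(c3cn(Cc4ccoc4)c4ccccc34)CC2)cc1C(=O)O`: 0.2 mg/kg

Compound 3 holds the middle place of the three numbers, with compound 2 lower and compound 1 higher, and both gaps lie beyond the scatter.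

The next compound to be measured is compound 4 `COc1ccc(CN2CCC(c3cn(Cc4ccc(Cl)s4)c4ccccc34)CC2)cc1C(=O)O`. It carries 5-chlorothiophen-2-yl in place of furan-3-yl on a saturated chain carbon bound to an aromatic nitrogen.

Within the data shown here, only one measured step falls at that place: a 2.5-fold higher number from compound 2 to compound 3 (0.40 log units; beyond the scatter). It is modest, though it exchanges a different pair of groups. The other measured step, a 5.0-fold lower number from compound 1 to compound 3 (0.70 log units; beyond the scatter), is also modest but concerns the methoxy group, which compound 4 retains, so it gives no direct guide to this change. Among the measured compounds shown here, no measured compound contains 5-chlorothiophen-2-yl, so the direction rests on little evidence. For the measured compounds named here, the one step at this place suggests that changes there stay modest in this assay, and no step beyond the scatter is expected here. The expected result is a 1.3-fold lower number from compound 3 to compound 4 (0.12 log units; within the scatter).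

For compound 4 the estimated value is 0.15 mg/kg, with an expected range of 0.05 mg/kg to 0.5 mg/kg.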

Compound 4, dose for half-maximal effect: 0.5 mg/kg
Compound 4: the middle estimate sits 3.3-fold (0.52 log units) below what was measured; the measured number falls inside the stated range.
By their numbers in this assay, from the lowest: compound 2; then compound 3; then compounds 4 and 1 (each within the scatter of the next).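

At the saturated chain carbon bound to an aromatic nitrogen, the exchange of one five-membered aromatic ring for another moves the number in this assay beyond the scatter: 5-chlorothiophen-2-yl in place of furan-3-yl gives a 2.5-fold higher number from compound 3 to compound 4 (0.40 log units; beyond the scatter). The earlier step at this place set propyl against a ring, so only now is it clear that the choice of ring itself counts; against propyl, the same group gives a 6.3-fold higher number from compound 2 to compound 4 (0.80 log units; beyond the scatter), and among these three compounds propyl carries the lowest number, with furan-3-yl next and 5-chlorothiophen-2-yl highest. Nothing available explains why the number moves at this place.

The chlorine and the sulfur enter together in a single step, so the compounds shown cannot assign the change to either one, and a thiophen-2-yl group carrying only hydrogen would be needed to separate them. Also open, from the compounds shown here alone, are how an amine or a longer chain would read at this place, and whether the methoxy step, a 5.0-fold lower number from compound 1 to compound 3 (0.70 log units; beyond the scatter), carries over to compounds bearing 5-chlorothiophen-2-yl.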